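Reversing the Linker Group of Compound 1

A few compounds are considered here, and "the series" means these few. Any claim that something is new, unique, unknown or untested is made for them only; others in the source may bear on it.

Measured so far:
Compound 1 `CC(C)Cc1cc(-c2ccc(Cn3ccnc3)cc2)c(S(=O)(=O)NC(=O)OC(C)C)s1`: > 10000 nM
Compound 2 `CC(C)Cc1cc(-c2ccc(Cn3ccnc3)cc2)c(S(=O)(=O)NC(=O)OC(C)(C)C)s1`: > 10000 nM

In an assay on membranes from liver for displacement of a labelled ligand from Type-2 angiotensin II receptor (Rattus norvegicus) (on this read-out higher numbers stand for weaker inhibition and lower numbers for stronger inhibition), compound 1 gives > 10000 nM, which is a limit of the assay and not a number. Compound 2 gives > 10000 nM, likewise a limit. Both values sit at the limit of > 10000 nM in this assay, at which 2 of the 2 values shown sit, so the step that the two limits leave unreadable from compound 1 to compound 2 cannot be read. Compound 3 `CCCCS(=O)(=O)NC(=O)c1sc(CC(C)C)cc1-c1ccc(Cn2ccnc2)cc1` differs from compound 1 by (butylsulfonyl)carbamoyl in place of (isopropoxycarbonyl)sulfamoyl on an aromatic carbon. Going by the values given here, no measured step bears on this change, so no direction beyond the scatter can be expected. Compound 3 is therefore estimated at 10000 nM, within 3000 nM to 30000 nM, and the expected step is a number no higher from compound 1 to compound 3 (the limit leaves the size open).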

Compound 3, inhibition constant: > 10000 nM
Compound 3: only a limit was reported; the forecaster's own chance of this, stated with the estimate: 70%; the middle value lies on the limit itself.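

Compound 1 and compound 3 each give only a limit of the assay and not a number, so no step between them can be read: the limit of > 10000 nM in this assay, at which 3 of the 3 values shown sit.

The compounds shown leave open how strongly any of them inhibits in this assay, and whether exchanging these groups changes that at all.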